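Halogen exchange on the aryl ring: lipophilicity notes

A few compounds are considered here, and "the series" means these few. Any claim that something is new, unique, unknown or untested is made for them only; others in the source may bear on it.

Measured so far:
compound 1 `C[C@H]1CC[C@@H]2[C@@H](OC(=O)[C@]23CC(c2ccc(Cl)cc2)=NO3)[C@]2(C)C(=O)C=C[C@@]12O` gives 2.09 in a physicochemical assay for lipophilicity; on this read-out lower numbers stand for lower lipophilicity and higher numbers for higher lipophilicity.
compound 2 `C[C@H]1CC[C@@H]2[C@@H](OC(=O)[C@]23CC(c2ccc(F)cc2)=NO3)[C@]2(C)C(=O)C=C[C@@]12O` gives 1.58 in this assay.
compound 3 `C[C@H]1CC[C@@H]2[C@@H](OC(=O)[C@]23CC(c2ccccc2Cl)N(c2ccccc2)O3)[C@]2(C)C(=O)C=C[C@@]12O` gives 3.87 in this assay.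

Compound 1 and compound 2 share a core and differ by fluoro in place of chloro on an aromatic carbon. The step is a number 0.51 log units lower from compound 1 to compound 2 (beyond the scatter). Compound 3 has a different core; the difference between the two cores is not broken down here. Compound 3 stands highest of the three, beyond the scatter of compound 1 and of compound 2.

Compound 4 `C[C@H]1CC[C@@H]2[C@@H](OC(=O)[C@]23CC(c2ccccc2F)N(c2ccccc2)O3)[C@]2(C)C(=O)C=C[C@@]12O` differs from compound 3 by fluoro in place of chloro on an aromatic carbon. The place is not the same word for word: in the first pair the halogen sits para to a large group, here ortho to a large group, so it is the same kind of change, not the same. The step from compound 3 to compound 4 is expected to be a number 0.50 log units lower from compound 3 to compound 4 (beyond the scatter) in this assay, resting on the earlier a number 0.51 log units lower from compound 1 to compound 2 (beyond the scatter). Compound 4 is estimated at 3.37, between 3 and 3.75.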

Compound 4, partition coefficient: 3.35
Beside the measured number, compound 4's estimate is 0.02 log units above it; the measured number falls inside the stated range.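

In this assay fluoro in place of chloro on an aromatic carbon gives a number 0.52 log units lower from compound 3 to compound 4 (beyond the scatter) and, on the other core, a number 0.51 log units lower from compound 1 to compound 2 (beyond the scatter); the change carried across these two cores at nearly the same size. This rests on two pairs only, with the halogen at a different place on the ring in each, so it gives no general rule for the series and does not separate the effect of the core from that of the place. Nothing shown bears on why the two steps agree.

The compounds shown leave open how a bromo, a methyl or an amine in the same place would stand. Going by these compounds, whether the step holds on any further core also stays open.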